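The source may report more compounds than this note shows. Statements on the series, on what has been measured and on what is new or still open speak of the compounds shown alone.

In a functional assay on HepG2 cells (Homo sapiens) for cytotoxicity, read by MTT assay, with a stated time of 24 h (on this read-out lower numbers stand for stronger inhibition and higher numbers for weaker inhibition), compound 1 (`COc1cc(/C=C2\CN(C)C/C(=C\c3cc(OC)c(OC)c(OC)c3)C2=O)cc(OC)c1`) gives 890 nM, compound 2 (`COc1cc(/C=C2\CN(C)C/C(=C\c3ccc(Cl)cc3Cl)C2=O)cc(OC)c1OC`) gives 8800 nM and compound 3 (`COc1cc(/C=C2\CN(C)C/C(=C\c3ccc(Cl)c(Cl)c3)C2=O)cc(OC)c1OC`) gives 6960 nM. Compound 3 thus lies within the scatter of compound 2, while compound 1 has the lowest number of the three. Compound 4 (`COc1cc(/C=C2\CN(C)C/C(=C\c3cccc([N+](=O)[O-])c3)C2=O)cc(OC)c1OC`) carries 3-nitrophenyl in place of 3,4-dichlorophenyl on a double-bonded chain carbon bound to a double-bonded ring carbon. Three measured steps change this same place: a 9.9-fold higher number from compound 1 to compound 2 (1.00 log units; beyond the scatter) and a 7.8-fold higher number from compound 1 to compound 3 (0.89 log units; beyond the scatter) are modest, whereas a 1.3-fold lower number from compound 2 to compound 3 (0.10 log units; within the scatter) stays within the scatter. None of them brings in 3-nitrophenyl, so no step beyond the scatter is expected in this assay. The estimated step is a 1.7-fold lower number from compound 3 to compound 4 (0.24 log units; within the scatter). For compound 4 the estimated value is 4000 nM, with an expected range of 1200 nM to 12000 nM.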

Compound 4, half-maximal inhibitory concentration: 1890 nM
For compound 4 the middle estimate is 2.1-fold (0.33 log units) above the measured one, and the stated range covers the measured number.
By their numbers in this assay, from the lowest: compound 1; then compound 4; then compounds 3 and 2 (each within the scatter of the next).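

In this assay this position, on a double-bonded chain carbon bound to a double-bonded ring carbon, separates a group without chlorine from both dichlorophenyl groups: 3-nitrophenyl gives a 3.7-fold lower number from compound 3 to compound 4 (0.57 log units; beyond the scatter) and a 4.7-fold lower number from compound 2 to compound 4 (0.67 log units; beyond the scatter). It does not reach 3,5-dimethoxyphenyl, however, with a 2.1-fold higher number from compound 1 to compound 4 (0.33 log units; beyond the scatter). No measured evidence bears on these differences. The compounds shown leave open whether an aminophenyl or a carboxyphenyl group at this place would fall nearer compound 1 or nearer compound 2 and compound 3.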